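Carbamate Change on the Shared Core

The source may report more compounds than this note shows. Statements on the series, on what has been measured and on what is new or still open speak of the compounds shown alone.

Compound 1 `COC(=O)N(Cc1ccccc1F)c1c(N)nc(-c2nn(Cc3ccccc3F)c3ncccc23)nc1N` gives 0.1 uM in an assay on cells for activation of Guanylate cyclase soluble subunit alpha-1 (Rattus norvegicus), read by cGMP accumulation and immunoassay, with a stated time of 10 min; a lower number here means that less compound is needed, a higher number that more compound is needed for the effect.
Compound 2 `COC(=O)N(Cc1cccc(F)c1)c1c(N)nc(-c2nn(Cc3ccccc3F)c3ncccc23)nc1N` gives 0.2 uM in this assay.
Compound 3 `CC(C)OC(=O)Nc1c(N)nc(-c2nn(Cc3ccccc3F)c3ncccc23)nc1N` gives 0.8 uM in this assay.

Among these three, compound 3 has the highest number, standing beyond the scatter from both compound 2 and compound 1. For the measured compounds named here, the only step measured between two compounds differing in one place, a 2.0-fold higher number from compound 1 to compound 2 (0.30 log units; within the scatter), lies within the scatter and concerns another part of the molecule. Compound 4 `Nc1nc(-c2nn(Cc3ccccc3F)c3ncccc23)nc(N)c1NC(=O)OCC(F)(F)F` differs from compound 3 in one place: 2,2,2-trifluoroethyl in place of isopropyl on an oxygen next to a carbonyl group. Going by the values given here, no measured step touches the oxygen next to the carbonyl group, so the data point in no direction for this change. Compound 4 is therefore expected to show a step of no change at the digits printed from compound 3 to compound 4 (within the scatter) in this assay, none beyond the scatter. The estimate for compound 4 is 0.8 uM, with a range from 0.3 uM to 2 uM.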

Compound 4, minimum effective concentration: 0.2 uM
For compound 4 the middle estimate is 4.0-fold (0.60 log units) above the measured one; measured number outside the range, below it.
By their numbers in this assay, from the lowest: compounds 1, 2 and 4 (each within the scatter of the next); then compound 3.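

For the compounds shown here, the oxygen next to a carbonyl group turns out to be a position that responds in this assay: 2,2,2-trifluoroethyl in place of isopropyl gives a 4.0-fold lower number from compound 3 to compound 4 (0.60 log units; beyond the scatter), the only step beyond the scatter between compounds differing in one place. No evidence bears on why this exchange lowers the number. Open, going by these compounds, is whether the fluorine atoms or the chain itself account for the step, as a plain ethyl or a longer chain such as n-butyl on this oxygen could show. Also open, on these data alone, is whether the step would carry over to compound 1, whose carbamate nitrogen bears a further group.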